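Solubility of compound 3 with a pentyl group

A few compounds are considered here, and "the series" means these few. Any claim that something is new, unique, unknown or untested is made for them only; others in the source may bear on it.

Measured in a physicochemical assay for solubility; on this read-out higher numbers stand for higher solubility and lower numbers for lower solubility:
compound 1 `Nc1cccc2c(=O)[nH]c(-c3ccccc3)cc12`: > 30000000 nM (a limit)
compound 2 `Nc1cccc2c(=O)[nH]c(-c3cccs3)cc12`: > 30000000 nM (a limit)

Compound 2 stands at > 30000000 nM, which is a limit of the assay and not a number. Going by the values given here, the only other value shown, that of compound 1, is a limit as well. The evidence therefore comes down to the limit of > 30000000 nM in this assay, at which 2 of the 2 values shown sit.

The next structure is compound 3 `CCCCCc1cc2c(N)cccc2c(=O)[nH]1`, which carries pentyl in place of thiophen-2-yl on an aromatic carbon, next to the ring nitrogen: pentyl in place of thiophen-2-yl on an aromatic carbon.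

Among the compounds with values here, only one measured step bears on this change: thiophen-2-yl in place of phenyl on an aromatic carbon, which is a step that the two limits leave unreadable from compound 1 to compound 2. It gives no size to carry over and says nothing about a pentyl group. Within the data shown here, the expectation thus rests on compound 2 and its limit of > 30000000 nM, with no direction of change expected in this assay and no step expected beyond the scatter.

The expected step is a number no higher from compound 2 to compound 3 (the limit leaves the size open). For compound 3 the estimated value is 30000000 nM, with an expected range of 8000000 nM to 60000000 nM.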

Compound 3, solubility: > 30000000 nM
Compound 3: no number, only a limit; the forecaster's own chance of this, stated with the estimate: 70%; the middle value sits exactly at the limit.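

In this assay, compound 3 gives > 30000000 nM, which is a limit of the assay and not a number. No step among compound 1, compound 2 and compound 3 can be read, and the evidence comes down to: the limit of > 30000000 nM in this assay, at which 3 of the 3 values shown sit.

The compounds shown leave open what the actual values are and whether phenyl, thiophen-2-yl and pentyl differ at all in this assay.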